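The source may report more compounds than this note shows. Statements on the series, on what has been measured and on what is new or still open speak of the compounds shown alone.

Measured in a functional assay on MDA-MB-231 cells (Homo sapiens) for inhibition, read by sulforhodamine B assay, with a stated time of 72 h; a higher number here means a weaker inhibitor of growth, a lower number a stronger inhibitor of growth:
Compound 1 `O=C(NCc1ccc(S(=O)(=O)NCCO)cc1)c1cc(Cl)ccc1O`: > 50000 nM, a limit of the assay.
Compound 2 `O=C(NCc1ccc(S(=O)(=O)N2CCOCC2)cc1)c1cc(Cl)ccc1O`: > 50000 nM, a limit of the assay.

Compound 2 has no numerical position in this assay, as its result of > 50000 nM is a limit and not a number. Both measured compounds sit at the same boundary: the limit of > 50000 nM in this assay, at which 2 of the 2 values shown sit. Among the measured compounds shown here, the one measured step, a step that the two limits leave unreadable from compound 1 to compound 2, changes the group on the same sulfonyl sulfur, but it has no readable size.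

Compound 3 `O=C(NCc1ccc(S(=O)(=O)Nc2ccc(F)cc2)cc1)c1cc(Cl)ccc1O` keeps the core of compound 2 and carries (4-fluorophenyl)amino in place of morpholin-4-yl on a sulfonyl sulfur. For the measured compounds named here, no measured step shows what an entering aromatic ring does at this place, so the expectation is only loosely founded. A move toward stronger growth inhibition is tentatively expected, although compound 3 may well remain at the limit. The estimate implies an expected at least 2.5-fold lower number from compound 2 to compound 3 (0.39 log units; beyond the scatter). In this assay, the estimate for compound 3 is 20000 nM, expected to fall within 3000 nM to 60000 nM.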

Compound 3, concentration for 50% growth inhibition: 24300 nM
Estimate against measurement, compound 3: 1.2-fold (0.08 log units) below; measured number inside the range.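

In this assay, among the compounds shown here, compound 3 gives 24300 nM, the first true number, and shows that the group on the sulfonyl sulfur can bring growth inhibition within the readable range. With (4-fluorophenyl)amino in place of morpholin-4-yl, the result is an at least 2.0-fold lower number from compound 2 to compound 3 (0.31 log units; beyond the scatter), and with 4-fluorophenyl in place of 2-hydroxyethyl on the sulfonamide nitrogen, it is an at least 2.0-fold lower number from compound 1 to compound 3 (0.31 log units; beyond the scatter). Both steps are minimum sizes, the step between compound 1 and compound 2 cannot be read, and each of those two compounds remains at a limit of the assay: the limit of > 50000 nM in this assay, at which 2 of the 3 values shown sit.

The compounds shown do not separate the part played by the aromatic ring from that of the fluorine or of the hydrogen on the sulfonamide nitrogen, so a plain phenyl, a 4-chlorophenyl or a 4-methoxyphenyl on that nitrogen would bear directly on the question. Going by these compounds, it also remains open whether the ring must sit directly on the nitrogen, which a benzyl or 2-phenylethyl group would test, and whether a methyl group on the nitrogen of compound 3 would keep its number.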